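Removing the Pyrrolidinyl Group from a Bis-benzylamine Antagonist

The compounds below may be only part of what the source reports. "The series", "measured", "known", "first", "only" and "open" are said of these compounds alone.

Measured so far:
compound 1, `c1ccc(NCc2ccc(CNc3ccccc3)cc2)cc1`: 64%
compound 2, `Clc1ccc(NCc2ccc(CNc3ncccn3)cc2)nc1`: 100%
compound 3, `c1cnc(NCc2ccc(CNc3cccc(N4CCCC4)c3)cc2)nc1`: 78%

In a functional assay on MDA-MB-231 cells for antagonist activity at C-X-C chemokine receptor type 4 (Homo sapiens), tested at 100 nM (on this read-out lower numbers stand for a weaker effect and higher numbers for a stronger effect at the one concentration tested), compound 3 gives 78%, the second highest of the three numbers. Its nearest neighbour is compound 1, whose value is lower by more than the usual scatter, and the furthest is compound 2, whose value is higher, again by more than the scatter. Going by the values given here, no pair of these three compounds differs in a single place, so none of the gaps between them can be tied to one structural change.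

Compound 4, `c1ccc(NCc2ccc(CNc3ncccn3)cc2)cc1`, is the compound that follows from compound 3 by one change: hydrogen in place of pyrrolidin-1-yl on an aromatic carbon. It keeps the pyrimidinyl amine of compound 3 and ends up, on the other side, with the same plain phenylamine that compound 1 carries. Nothing measured here shows what the pyrrolidin-1-yl group contributes on its own, so the expectation rests on the general spread of the three values. The closest measured compound in shape to compound 4 is compound 1, which gives 64%. In this assay the step is expected to be a modest decrease, a number 10 percentage points lower from compound 3 to compound 4 (within the scatter), possibly not beyond the scatter. Compound 4 is therefore estimated at 68%, with a likely range from 50% to 85%.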

Compound 4, a percentage reported as inhibition, at one concentration (the size of the read-out at that concentration, not a potency): 100%
Compound 4: middle estimate off by 32 percentage points, on the low side, and the stated range ends below it.
By their numbers in this assay, from the lowest: compound 1; then compound 3; then compounds 2 and 4 (each within the scatter of the next).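

In this assay, hydrogen serves better than pyrrolidin-1-yl on this aromatic carbon, with a number 22 percentage points higher from compound 3 to compound 4 (beyond the scatter), so the effect at the one concentration tested does not depend on that ring being present. On an amine nitrogen, pyrimidin-2-yl in place of phenyl gives a number 36 percentage points higher from compound 1 to compound 4 (beyond the scatter), the first measure of what this single change is worth in a compound that otherwise carries plain phenylamine. On the other amine nitrogen, phenyl in place of 5-chloropyridin-2-yl gives no change at the digits printed from compound 2 to compound 4 (within the scatter), so once the pyrimidin-2-yl group is in place, the read-out does not separate these two groups. Nothing available here explains any of these steps.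

Going by these compounds, it remains open whether a smaller substituent on the same aromatic carbon, such as a dimethylamino or methoxy group, would keep the number of compound 4 or lose part of it, as pyrrolidin-1-yl does. Compound 2 and compound 4 also print the same value at a single concentration, so whether they would still match at lower concentrations is unsettled, as is the effect of an unsubstituted pyridin-2-yl group on that nitrogen.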